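From a Cyclohexyl Ring to an Open Pentan-3-yl Chain

A few compounds are considered here, and "the series" means these few. Any claim that something is new, unique, unknown or untested is made for them only; others in the source may bear on it.

Three compounds share one core and differ only in the ring carried on a nitrogen on an aromatic ring. In a functional assay (Nicotiana tabacum) (on this read-out lower numbers stand for stronger inhibition and higher numbers for weaker inhibition), compound 1 `CSc1nc(NC2CC2)c2cccnc2n1` gives 4900 nM and compound 2 `CSc1nc(NC2CCC2)c2cccnc2n1` gives 720 nM. Compound 3 `CSc1nc(NC2CCCCC2)c2cccnc2n1` gives 5650 nM, the highest number of the three, though the step of a 1.2-fold higher number from compound 1 to compound 3 (0.06 log units; within the scatter) stays within the scatter. Compound 4 `CCC(CC)Nc1nc(SC)nc2ncccc12` places pentan-3-yl in place of cyclohexyl, which swaps the ring for an open chain: pentan-3-yl in place of cyclohexyl on a nitrogen on an aromatic ring.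

Going by the values given here, no measured step involves an open chain, so the evidence is indirect. The ring changes give a 6.8-fold lower number from compound 1 to compound 2 (0.83 log units; beyond the scatter) and a 7.8-fold higher number from compound 2 to compound 3 (0.89 log units; beyond the scatter), both modest, and only compound 2 720 nM departs from the high end. Moving away from cyclohexyl therefore need not change much, and no step beyond the scatter is expected in this assay, with a slight lean towards a lower number. The estimated change is a 1.6-fold lower number from compound 3 to compound 4 (0.21 log units; within the scatter). For compound 4 the expected value is 3500 nM, within an estimated range of 1000 nM to 11000 nM.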

Compound 4, half-maximal inhibitory concentration: 2720 nM
Compound 4: the middle estimate sits 1.3-fold (0.11 log units) above what was measured, and the stated range covers the measured number.
By their numbers in this assay, from the lowest: compound 2; then compounds 4, 1 and 3 (each within the scatter of the next, the first and the last beyond it).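

Replacing the ring with an open chain in this assay gives a 2.1-fold lower number from compound 3 to compound 4 (0.32 log units; beyond the scatter), so a ring on this nitrogen is not required for inhibition at this level. Going by these compounds alone, the open chain still does not match the best ring, with a 3.8-fold higher number from compound 2 to compound 4 (0.58 log units; beyond the scatter), and cyclobutyl remains the only group here clearly separated from all the others. Against cyclopropyl, pentan-3-yl gives a 1.8-fold lower number from compound 1 to compound 4 (0.26 log units; within the scatter), so these two groups cannot be told apart in this assay.

Nothing shown explains why these groups differ. Going by these compounds, it also remains open whether a smaller branched chain such as isopropyl, a longer chain such as heptan-4-yl, or a chain carrying an amine would keep, improve or lose this level of inhibition.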